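Cytotoxicity in the indole-acid series: free acid versus ethyl ester

This account rests on a few compounds, and the source may have more. Where it says the series, first, only, none or still open, it means among the compounds named here.

Measured so far:
compound 1 `COc1cccc2c1c(C(=O)/C=C(\O)C(=O)O)cn2Cc1ccccc1F`: 70500 nM
compound 2 `COc1cccc2c1c(C(=O)/C=C(\O)C(=O)O)cn2Cc1ccc(F)c(F)c1F`: 22800 nM
compound 3 `CCOC(=O)/C(O)=C/C(=O)c1cn(Cc2ccc(F)c(F)c2F)c2cccc(OC)c12`: 42700 nM

In an ADME assay on MT4 cells (Homo sapiens) for cytotoxicity, read by MTT assay (a higher number here means that more compound is tolerated, a lower number that less compound is tolerated), compound 2 gives 22800 nM and compound 1 gives 70500 nM. The change between them is 2-fluorophenyl in place of 2,3,4-trifluorophenyl on a saturated chain carbon bound to an aromatic nitrogen, and it made the step of a 3.1-fold higher number from compound 2 to compound 1 (0.49 log units; beyond the scatter). Compound 3 carries a different core from compound 2, the difference being (ethyl in place of hydrogen on an oxygen next to a carbonyl group), with the step of a 1.9-fold higher number from compound 2 to compound 3 (0.27 log units; within the scatter).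

Compound 4 `CCOC(=O)/C(O)=C/C(=O)c1cn(Cc2ccccc2F)c2cccc(OC)c12` is not yet measured in this assay. Among the compounds with values here, it differs from compound 3 by 2-fluorophenyl in place of 2,3,4-trifluorophenyl on a saturated chain carbon bound to an aromatic nitrogen, which is the same change as the one from compound 2 to compound 1: the place is the same, only the core differs. Since the step from compound 2 to compound 1 was a 3.1-fold higher number from compound 2 to compound 1 (0.49 log units; beyond the scatter), and compound 3 stands at 42700 nM, a step of similar size is expected from compound 3 to compound 4, a 2.6-fold higher number from compound 3 to compound 4 (0.41 log units; beyond the scatter). Compound 4 is therefore estimated at 110000 nM, expected to fall between 50000 nM and 250000 nM. This rests on one step only; a cap of the assay is possible at such a high number.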

Compound 4, half-maximal cytotoxic concentration: 63300 nM
Compound 4: middle estimate off by 1.7-fold (0.24 log units), on the high side; low and high end bracket the measured number.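

In this assay, 2-fluorophenyl in place of 2,3,4-trifluorophenyl on the core of compound 3 gives a 1.5-fold higher number from compound 3 to compound 4 (0.17 log units; within the scatter), and this step does not differ meaningfully from the earlier one: the same change on two cores in this assay, a 3.1-fold higher number (0.49 log units; beyond the scatter) from compound 2 to compound 1 and a 1.5-fold higher number (0.17 log units; within the scatter) from compound 3 to compound 4, 2.1-fold (0.32 log units) apart, within the scatter of two such steps

Ethyl in place of hydrogen on the oxygen next to a carbonyl group, now taken on the core of compound 1, gives a 1.1-fold lower number from compound 1 to compound 4 (0.05 log units; within the scatter), and the comparison reads the same way: the same change on two cores in this assay, a 1.9-fold higher number (0.27 log units; within the scatter) from compound 2 to compound 3 and a 1.1-fold lower number (0.05 log units; within the scatter) from compound 1 to compound 4, 2.1-fold (0.32 log units) apart, within the scatter of two such steps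

Both changes are therefore compatible with carrying from one core to the other in these four compounds, but one pair per core cannot show that a step keeps its size, since the fluorine change is beyond the scatter on one core and within it on the other.

Still open, as far as these compounds go, is whether this holds for other groups at the same place, such as an unsubstituted phenyl or a pyridine ring. Also open, from the compounds shown here alone, is whether it holds with a longer chain on the ester oxygen or an amide in place of the ester.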